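The compounds below may be only part of what the source reports. "The series", "measured", "known", "first", "only" and "open" are said of these compounds alone.

Series notes, step from compound 2 to compound 3.

Among the measured compounds shown here, compound 1 `CCn1nc(-c2cccnc2)c2ccccc2c1=O` and compound 2 `O=C(c1cccs1)n1nc(-c2cccnc2)c2ccccc2c1=O` are the two compounds measured so far in an assay on isolated protein (Oryctolagus cuniculus) with Thromboxane-A synthase (Homo sapiens) as the target, tested at 1 uM; on this read-out lower numbers stand for less inhibition and higher numbers for more inhibition at the one concentration tested (going by the name of the read-out). Compound 1 gives 87% in this assay, and compound 2 gives 37%. For the measured compounds named here, the one step between them, a number 50 percentage points lower from compound 1 to compound 2 (beyond the scatter), is the single piece of evidence on the effect of the substituent on the aromatic nitrogen. Compound 2 therefore stands lowest of the two numbers, with compound 1 the nearest neighbour and clearly higher.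

Compound 3 `O=c1c2ccccc2c(-c2cccnc2)nn1CCO` is not yet measured. It differs from compound 2 as follows: 2-hydroxyethyl in place of (thiophen-2-yl)carbonyl on an aromatic nitrogen. Going by the values given here, the only relevant comparison is the step from compound 1 to compound 2, which was large and downward; compound 3 reverses the kind of group in that same place, carrying a short chain rather than a carbonyl-linked ring, so an upward step is expected, a number 38 percentage points higher from compound 2 to compound 3 (beyond the scatter), of a size comparable to the one seen. Compound 3 is thus estimated to reach about 75% in this assay, with a range of 50% to 92%.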

Compound 3, a percentage reported as inhibition, at one concentration (the size of the read-out at that concentration, not a potency): 69%
Compound 3: the middle estimate sits 6 percentage points above what was measured; the range from low to high includes it.
By their numbers in this assay, from the lowest: compound 2; then compound 3; then compound 1.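

In this assay the step of a number 32 percentage points higher from compound 2 to compound 3 (beyond the scatter) shows that the low number of compound 2 does not extend to every replacement of ethyl on this aromatic nitrogen, since 2-hydroxyethyl in place of (thiophen-2-yl)carbonyl recovers much of the inhibition. The change from ethyl to 2-hydroxyethyl is not neutral either: hydroxy in place of hydrogen on the saturated chain gives a number 18 percentage points lower from compound 1 to compound 3 (beyond the scatter), which leaves the hydroxylated chain between the other two groups. No measurement at hand bears on the reason for either step.

The compounds shown do not separate the carbonyl link from the thiophene ring within the group of compound 2. As far as these compounds go, how an amine or a carboxylic acid in place of the hydroxy, or a longer chain, would read in this assay also stays open.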